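Bromo to hydroxy at the chain end of compound 2

The source may hold more compounds than are shown below. What is called first, only, known or untested is meant among the compounds shown, and "the series" means these compounds.

In a functional assay on HL-60 cells (Homo sapiens) for cytotoxicity, read by MTT assay, with a stated time of 24 h (a lower number here means a stronger inhibitor, a higher number a weaker inhibitor), compound 2 (`BrCCCOc1c(Br)cc(Br)cc1Oc1ccc(Br)cc1Br`) gives 29.9 ug/mL, compound 3 (`Brc1ccc(Oc2cc(Br)cc(Br)c2OCCCCCN2CCN(c3ccccc3)CC2)c(Br)c1`) gives 41.6 ug/mL and compound 1 (`CC(C)(C)OC(=O)N1CCCN(CCCCCOc2c(Br)cc(Br)cc2Oc2ccc(Br)cc2Br)CC1`) gives 44.8 ug/mL. Compound 2 thus stands within the usual scatter of both other compounds, and the three numbers cannot be ranked on these data.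

The next compound to be read is compound 4 (`OCCCOc1c(Br)cc(Br)cc1Oc1ccc(Br)cc1Br`), which has hydroxy in place of bromo on a saturated chain carbon, three bonds along the chain from an oxygen on an aromatic ring. Going by the values given here, no measured pair shows this exchange on its own. Among the compounds with values here, the only guide is that the chains of compound 1 at 44.8 ug/mL and compound 3 at 41.6 ug/mL differ from that of compound 2 at 29.9 ug/mL, yet all three values remain within the scatter. No change beyond the scatter is therefore expected in this assay, and the expected step is a 1.3-fold higher number from compound 2 to compound 4 (0.10 log units; within the scatter). For compound 4 the estimated value is 38 ug/mL, with an expected range of 19 ug/mL to 75 ug/mL.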

Compound 4, half-maximal inhibitory concentration: 29.9 ug/mL
Compound 4: the middle estimate sits 1.3-fold (0.10 log units) above what was measured, and the stated range covers the measured number.
By their numbers in this assay, from the lowest: compounds 2, 4, 3 and 1 (each within the scatter of the next).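

Going by these compounds alone, the exchange of bromo for hydroxy on a saturated chain carbon, three bonds along the chain from an oxygen on an aromatic ring, is the first change that can be read in one place. In this assay it gives no change at the digits printed from compound 2 to compound 4 (within the scatter) and so shows that the bromo of compound 2 is not required for the reading at this chain end, where a group with no hydrogen-bond donor or acceptor and a group with one of each read alike. No measurement shown gives a reason for this outcome.

On these data alone, whether an amine or a carboxylic acid at the chain end would read the same remains open. So does the effect of a longer chain ending in hydroxy, since compound 1 and compound 3 differ from compound 2 in more than one place.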